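A few compounds are considered here, and "the series" means these few. Any claim that something is new, unique, unknown or untested is made for them only; others in the source may bear on it.

Measured compounds in an assay on Sf9 cells for inhibition of serine/threonine-protein kinase 4 (Homo sapiens), read by luminescence and ADP-Glo, with a stated time of 1 h, in the presence of a further agent that is not named here; a higher number here means a weaker inhibitor, a lower number a stronger inhibitor:

- compound 1, `CN1CC(=O)N(C)c2cnc(Nc3ccc(S(N)(=O)=O)cc3)nc21`, gives 495 nM
- compound 2, `CC(C)C1C(=O)N(C)c2cnc(Nc3ccc(S(N)(=O)=O)cc3)nc2N1C`, gives 254 nM
- compound 3, `CN1C(=O)C(CC2CC2)N(C)c2nc(Nc3ccc(S(N)(=O)=O)cc3)ncc21`, gives 211 nM

Compound 3 holds the lowest of the three numbers in this assay. Its separation from compound 2 is within the scatter, so no order between those two can be drawn; its separation from compound 1 is modest but beyond the scatter.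

Compound 4, `CN1C(=O)C(c2ccc(F)cc2)N(C)c2nc(Nc3ccc(S(N)(=O)=O)cc3)ncc21`, is not yet measured. It differs from compound 3 in one place: 4-fluorophenyl in place of cyclopropylmethyl on a saturated ring carbon.

Among the measured compounds shown here, three measured steps concern this same saturated ring carbon. Putting isopropyl in place of hydrogen gave a 1.9-fold lower number from compound 1 to compound 2 (0.29 log units; within the scatter). Putting cyclopropylmethyl in place of hydrogen gave a 2.3-fold lower number from compound 1 to compound 3 (0.37 log units; beyond the scatter). Exchanging isopropyl for cyclopropylmethyl gave a 1.2-fold lower number from compound 2 to compound 3 (0.08 log units; within the scatter). Taken together, variation at this carbon has so far moved the number only slightly, and exchanging one substituent for another hardly at all. An aromatic group has not been placed here before, so the bearing of these steps on compound 4 is limited.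

The expectation is therefore a step of a 1.1-fold lower number from compound 3 to compound 4 (0.05 log units; within the scatter) in this assay, with a wide range to reflect the lack of any aryl precedent. Compound 4 is estimated at 190 nM, expected between 55 nM and 650 nM.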

Compound 4, half-maximal inhibitory concentration: 1770 nM
Estimate against measurement, compound 4: 9.3-fold (0.97 log units) below; the whole stated range lies below it.
By their numbers in this assay, from the lowest: compounds 3, 2 and 1 (each within the scatter of the next, the first and the last beyond it); then compound 4.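

In this assay the saturated ring carbon proved less tolerant than the alkyl groups suggested: 4-fluorophenyl in place of cyclopropylmethyl gives an 8.4-fold higher number from compound 3 to compound 4 (0.92 log units; beyond the scatter) and in place of isopropyl gives a 7.0-fold higher number from compound 2 to compound 4 (0.84 log units; beyond the scatter), whereas those two alkyl groups lie within the scatter of each other. Among the compounds shown here, the change also carries the number past that of the compound with hydrogen at this carbon, with a 3.6-fold higher number from compound 1 to compound 4 (0.55 log units; beyond the scatter), so a substituent here can raise the number as well as leave it little changed or lower it modestly; compound 4 is the only compound that goes the upward way, and it alone carries an aromatic group at this carbon. Nothing available explains the loss.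

Open, from the compounds shown here alone, is whether the higher number goes with the aromatic ring itself or with the fluorine on it, a question that plain phenyl, and benzyl with its one-carbon link to the ring, would help to separate. Also open, going by these compounds, is how this carbon responds to a group of another kind, such as an amine, a carboxylic acid or a longer alkyl chain.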